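The source may report more compounds than this note shows. Statements on the series, on what has been measured and on what is new or still open speak of the compounds shown alone.

Compound 2 `CCCS(=O)(=O)Nc1ccc(F)c(C(=O)Nc2cnc3[nH]nc(C)c3c2)c1F` stands highest of the two compounds measured in a physicochemical assay for solubility, read by HPLC, in phosphate buffer, with a stated time of 24 h, at pH 6.5 (on this read-out higher numbers stand for higher solubility and lower numbers for lower solubility), where compound 2 gives 380 ug/mL. The nearest is compound 1 `CCCS(=O)(=O)Nc1ccc(F)c(C(=O)Nc2cnc3[nH]ncc3c2)c1F`, which in this assay gives 80 ug/mL. Among the compounds with values here, the single measured step, a 4.8-fold higher number from compound 1 to compound 2 (0.68 log units; beyond the scatter), comes from a methyl in place of a hydrogen on an aromatic carbon. Compound 3 `CCCS(=O)(=O)Nc1ccc(F)c(C(=O)Nc2cnc3[nH]nc(N(C)C)c3c2)c1F` differs from compound 2 by dimethylamino in place of methyl on an aromatic carbon. Within the data shown here, no measured step swaps a methyl for a dimethylamino, so the step from compound 1 to compound 2 bears on it only loosely: it shows that a small change at an aromatic carbon of the five-membered aromatic ring with two nitrogens can shift solubility beyond the scatter, without saying which way a dimethylamino would shift it. A step of about a 1.3-fold lower number from compound 2 to compound 3 (0.10 log units; within the scatter) is therefore expected, not clearly beyond the scatter. For compound 3 the estimate in this assay is 300 ug/mL, with a range from 100 ug/mL to 900 ug/mL.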

Compound 3, solubility: 290 ug/mL
For compound 3 the middle estimate is 1.0-fold (0.01 log units) above the measured one; low and high end bracket the measured number.
By their numbers in this assay, from the lowest: compound 1; then compounds 3 and 2 (each within the scatter of the next).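

In this assay, dimethylamino in place of methyl on this aromatic carbon gives a 1.3-fold lower number from compound 2 to compound 3 (0.12 log units; within the scatter), so the two groups cannot be told apart on this read-out. Dimethylamino in place of hydrogen on the same carbon gives a 3.6-fold higher number from compound 1 to compound 3 (0.56 log units; beyond the scatter), so a second group, this one holding a nitrogen, also stands apart from hydrogen, which the single methyl step could not show. No measurement at hand explains this result. The compounds shown leave open whether the same gap from hydrogen holds for other kinds of group on this carbon, such as a carboxylic acid or a longer carbon chain. They also leave open whether a ring amine such as morpholine would match dimethylamino and methyl here.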